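Swapping the furan for an imidazole on the anilino chain

The compounds below may be only part of what the source reports. "The series", "measured", "known", "first", "only" and "open" are said of these compounds alone.

Three compounds carrying the same chloro-substituted aryl ketone motif have been examined in an ADME assay on Vero cells (Chlorocebus sabaeus) for cytotoxicity, with a stated time of 72 h; a lower number here means that less compound is tolerated, a higher number that more compound is tolerated. Compound 1 `CN(C)CCCc1ccc(C(=O)/C=C/c2ccc(Cl)cc2)cc1` gives 5.92 ug/mL. Compound 2 `O=C(c1ccc(NCc2ccco2)cc1)C1CC1c1ccc(Cl)cc1` gives 256 ug/mL, and compound 3 `CCCCCCCC/C=C\CCCCCCCCNc1ccc(C(=O)C2CC2c2ccc(Cl)cc2)cc1` gives 393 ug/mL. On these numbers compound 2 sits together with compound 3, the two within the usual scatter of each other. The gap between compound 2 and compound 1 lies well beyond the scatter. The shared cyclopropyl ketone core of compound 2 and compound 3 is thus tolerated at far higher concentration than the enone of compound 1, with the present data.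

Compound 4 `O=C(c1ccc(NCCn2ccnc2)cc1)C1CC1c1ccc(Cl)cc1` is the next member to be tested in this assay. It differs from compound 2 in one place: (1H-imidazol-1-yl)methyl in place of furan-2-yl on a saturated chain carbon bound to a nitrogen on an aromatic ring. The substituent on the saturated chain carbon bound to the aromatic nitrogen remains a small five-membered aromatic ring, and the two tolerated compounds differ widely in what they carry on that nitrogen, so no step beyond the scatter is expected here in either direction. The step from compound 2 to compound 4 is estimated at a 1.3-fold lower number from compound 2 to compound 4 (0.11 log units; within the scatter). Compound 4 is accordingly expected to give about 200 ug/mL, with a range from 60 ug/mL to 500 ug/mL.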

Compound 4, half-maximal cytotoxic concentration: 243 ug/mL
Compound 4: the middle estimate sits 1.2-fold (0.08 log units) below what was measured; the measured number falls inside the stated range.
By their numbers in this assay, from the lowest: compound 1; then compounds 4, 2 and 3 (each within the scatter of the next).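

In this assay, putting (1H-imidazol-1-yl)methyl in place of furan-2-yl on a saturated chain carbon bound to a nitrogen on an aromatic ring comes to a 1.1-fold lower number from compound 2 to compound 4 (0.02 log units; within the scatter) and so stays within the usual scatter. For the compounds shown here, compound 1, compound 2 and compound 3 offered no pair differing in one place, so this is the first reading of a single change at this position, and it shows that one more heavy atom and a ring with two hetero atoms rather than one leave the two compounds indistinguishable in this measurement. No measurement at hand speaks to why the two compounds read alike.

Both groups compared here carry a five-membered aromatic ring, so the compounds shown leave open how this position responds when the ring gives way to a carboxylic acid, a morpholine or a simple dimethylamino group. They also leave open whether a phenyl ring, or a longer chain between the imidazole and the aromatic nitrogen, would stay within the scatter of compound 2 in this assay.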